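The compounds below may be only part of what the source reports. "The series", "measured", "known", "first", "only" and "open" are said of these compounds alone.

Compound 1 `Cc1cc(C(=O)O)nn1Cc1cc(Br)ccc1OCc1ccccc1`: 6.46 nM
Compound 2 `O=C(O)c1nn(Cc2cc(Br)ccc2OCc2ccccc2)cc1CO`: 676 nM

Both compounds were tested in an assay on CHO-K1 cells for displacement of a labelled ligand from prostaglandin E2 receptor EP1 subtype (Homo sapiens); a higher number here means a weaker inhibitor, a lower number a stronger inhibitor. Compound 1 gives 6.46 nM, the lowest of the two numbers; compound 2, with 676 nM, sits far above it, well beyond the scatter of repeated measurements, so compound 1 is the stronger inhibitor of the two.

Compound 3 `Cc1cccc(COc2ccc(Br)cc2Cn2nc(C(=O)O)cc2C)c1` has not yet been measured. It differs from compound 1 in one place: methyl in place of hydrogen on an aromatic carbon. The methyl enters on an aromatic carbon of a six-membered aromatic ring of carbon only, meta to a large group; cut one bond further out, the change reads benzyl to 3-methylbenzyl.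

Within the data shown here, no pair of measured compounds here isolates such a change, so there is no direct precedent, and nothing in the two numbers points to a large shift from one added methyl. The step of a 1.0-fold higher number from compound 1 to compound 3 (0.00 log units; within the scatter) is expected to stay within the scatter, with no clear direction. Compound 3 is therefore estimated at 6.5 nM, with a range from 2 nM to 20 nM.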

Compound 3, half-maximal inhibitory concentration: 126 nM
Compound 3: middle estimate off by 19-fold (1.29 log units), on the low side; measured number outside the range, above it.
By their numbers in this assay, from the lowest: compound 1; then compound 3; then compound 2.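

In this assay, replacing the benzyl group of compound 1 with 3-methylbenzyl gives a 20-fold higher number from compound 1 to compound 3 (1.29 log units; beyond the scatter), so a single methyl on this ring, meta to a large group, is enough to weaken inhibition markedly. The earlier compounds shown here could not show this, since both carry the plain benzyl group and say nothing about how this ring tolerates change. No measurement shown here speaks to why the number rises.

The compounds shown leave open whether this loss is particular to methyl or would also follow from another group at this place, such as fluorine, chlorine or methoxy. From the compounds shown here alone, it also remains open whether a methyl on one of the other carbons of this ring would give a similar step.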